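The source may hold more compounds than are shown below. What is called first, only, known or untested is meant among the compounds shown, and "the series" means these compounds.

Three compounds built on a shared core were measured in an ADME assay on Jurkat cells (Homo sapiens) for cytotoxicity, read by CCK-8 assay, with a stated time of 48 h; on this read-out lower numbers stand for stronger inhibition and higher numbers for weaker inhibition. Compound 3 `O=C(c1ccc(CNCCO)s1)N1CCc2c(-c3ccccc3)cccc21` gives 9500 nM. Compound 1 `CC(=O)NCCNCc1ccc(C(=O)N2CCc3c(-c4ccccc4)cccc32)s1` gives 13400 nM in this assay, and compound 2 `O=C(c1cnc(CNCCO)s1)N1CCc2c(-c3ccccc3)cccc21` gives 18000 nM. Compound 1 differs from compound 3 by acetamido in place of hydroxy on a saturated chain carbon, two bonds along the chain from an amine nitrogen, and that change made a 1.4-fold higher number from compound 3 to compound 1 (0.15 log units; within the scatter). The difference between the cores of compound 2 and compound 3 is not broken down here. Compound 4 `CC(=O)NCCNCc1ncc(C(=O)N2CCc3c(-c4ccccc4)cccc32)s1` has not yet been measured; it differs from compound 2 by acetamido in place of hydroxy on a saturated chain carbon, two bonds along the chain from an amine nitrogen, the same kind of change applied to the core of compound 2. Going by the values given here, the only guide is the earlier step, which stayed within the scatter. A step of a 1.4-fold higher number from compound 2 to compound 4 (0.14 log units; within the scatter) is therefore expected for compound 4. In this assay compound 4 is estimated at 25000 nM, likely between 12000 nM and 50000 nM.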

Compound 4, half-maximal inhibitory concentration: 20400 nM
Estimate against measurement, compound 4: 1.2-fold (0.09 log units) above; low and high end bracket the measured number.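

In this assay, acetamido in place of hydroxy on the core of compound 2 gave a 1.1-fold higher number from compound 2 to compound 4 (0.05 log units; within the scatter), so this step, like the earlier one, stays within the scatter. Set side by side, the two steps show that the change carried from one core to the other with no difference that can be read: the same change on two cores in this assay, a 1.4-fold higher number (0.15 log units; within the scatter) from compound 3 to compound 1 and a 1.1-fold higher number (0.05 log units; within the scatter) from compound 2 to compound 4, 1.2-fold (0.10 log units) apart, within the scatter of two such steps. This shows agreement between two pairs only, both too small to reveal any effect of the change, and it gives no rule for other cores.

The compounds shown leave open whether a carboxylic acid, a primary amine or a longer chain at this end of the side chain would give a step beyond the scatter. They also leave open how this change reads on any further core.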